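Extending a side chain on the shared core

The source may report more compounds than this note shows. Statements on the series, on what has been measured and on what is new or still open speak of the compounds shown alone.

Compound 3 `CCCCNC(=O)c1cc(CC)sc1N` is known only through a limit: in an assay on isolated protein for inhibition of Polyunsaturated fatty acid lipoxygenase ALOX15 (Homo sapiens), read by spectrophotometry, with a stated time of 10 min (a lower number here means a stronger inhibitor, a higher number a weaker inhibitor), compound 3 gives >= 50000 nM, which is a limit of the assay rather than a number. Compound 2 `CCCCNC(=O)c1cc(C)sc1N` likewise gives >= 50000 nM, again a limit. Compound 1 `Nc1sc(-c2ccccc2)cc1C(=O)NCCCCc1ccccc1` gives >= 50000 nM, also a limit. The step that the two limits leave unreadable from compound 2 to compound 3 therefore cannot be read. Compound 4 `CCCCNC(=O)c1cc(CCC)sc1N` differs from compound 3 by methyl in place of hydrogen on a saturated chain carbon, two bonds along the chain from an aromatic carbon. Among the compounds with values here, because of the limit of >= 50000 nM in this assay, at which 3 of the 3 values shown sit, no measured step bears on this change, and no direction beyond the scatter can be expected in this assay. Compound 4 is therefore expected to remain at the limit, the expected step of a number no higher from compound 3 to compound 4 (the limit leaves the size open) amounting to no change. The estimate for compound 4 is 50000 nM, ranging from 20000 nM to 200000 nM.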

Compound 4, half-maximal inhibitory concentration: >= 50000 nM
Compound 4: a limit, no number; the forecaster's own chance of this, stated with the estimate: 85%; the middle value sits exactly at the limit.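

Within the data shown here, compound 4 gives only a limit, as do compound 2 and compound 3, so no new step among them can be read: the limit of >= 50000 nM in this assay, at which 4 of the 4 values shown sit. The compounds shown leave open whether changing this chain on the shared core alters inhibition in this assay at all.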